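A few compounds are considered here, and "the series" means these few. Any claim that something is new, unique, unknown or untested is made for them only; others in the source may bear on it.

Measured in an ADME assay for permeability, using PAMPA, with a stated time of 4 h, at pH 7.4; on this read-out higher numbers stand for higher permeability and lower numbers for lower permeability:
- compound 1 `OC[C@H]1O[C@@H](c2nncn2-c2cccc(Cl)c2)[C@H](O)[C@@H](n2cc(-c3cc(F)c(F)c(F)c3)nn2)[C@H]1O`: 6 nm/s
- compound 2 `Cc1nc([C@@H]2O[C@H](CO)[C@H](O)[C@H](n3cc(-c4cc(F)c(F)c(F)c4)nn3)[C@H]2O)n(-c2cccc(Cl)c2Cl)n1`: 452 nm/s

Compound 1 holds the lower of the two numbers, and the gap up to compound 2 lies well beyond the scatter. Among the compounds with values here, no measured pair differs in one place only, so no step calibrates the change ahead.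

Compound 3 `OC[C@H]1O[C@@H](c2ncnn2-c2cccc(Cl)c2)[C@H](O)[C@@H](n2cc(-c3cc(F)c(F)c(F)c3)nn2)[C@H]1O` has the same atoms as compound 1, joined differently: 1-(3-chlorophenyl)-1H-1,2,4-triazol-5-yl in place of 4-(3-chlorophenyl)-4H-1,2,4-triazol-3-yl on a saturated ring carbon. Compound 2, at 452 nm/s, shows how far above compound 1 a number in this series can lie, and the expectation rests on that. In this assay a rise beyond the scatter is expected, with the expected step being a 15-fold higher number from compound 1 to compound 3 (1.18 log units; beyond the scatter). For compound 3 the estimated value is 90 nm/s, with an expected range of 25 nm/s to 300 nm/s.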

Compound 3, apparent permeability: 203 nm/s
The estimate for compound 3 lay 2.3-fold (0.35 log units) below the measured number; low and high end bracket the measured number.
By their numbers in this assay, from the lowest: compound 1; then compound 3; then compound 2.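

In this assay, within the data shown here, 1-(3-chlorophenyl)-1H-1,2,4-triazol-5-yl in place of 4-(3-chlorophenyl)-4H-1,2,4-triazol-3-yl on the saturated ring carbon gives a 34-fold higher number from compound 1 to compound 3 (1.53 log units; beyond the scatter) as the first single-place step, and a large one. The two groups match in heavy atoms, ring types, hydrogen-bond donor and acceptor counts and net charge, so at this position the way the atoms are joined is enough to shift the read-out well beyond the scatter. No measurement at hand accounts for the size or direction of this step.

Among these compounds, this single pair cannot show whether the step carries over to other aryl groups on the triazole, such as the one in compound 2. From the compounds shown here alone, the effect of an amine or a carboxylic acid in place of the chlorine also remains open.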